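Benzyl ether change at the limit of the assay

The source may hold more compounds than are shown below. What is called first, only, known or untested is meant among the compounds shown, and "the series" means these compounds.

Working notes on a functional assay on HUVEC cells (Homo sapiens) for antiproliferative activity, read by MTT assay, with a stated time of 24 h; a lower number here means a stronger inhibitor, a higher number a weaker inhibitor. Compound 1 `COc1cccc(C(=O)Oc2ccc3c(=O)c(-c4cc(OC)c(OC)cc4OC)coc3c2)c1` gives > 10000 nM, which is a limit of the assay and not a number. Compound 2 `COc1cc(OC)c(-c2coc3cc(OCc4ccc(F)cc4)ccc3c2=O)cc1OC` gives > 10000 nM, again only a limit. Both compounds therefore stand at the limit of > 10000 nM in this assay, at which 2 of the 2 values shown sit, and compound 2 has no exact position on the scale.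

Compound 3 `COc1cc(OC)c(-c2coc3cc(OCc4ccccc4C(F)(F)F)ccc3c2=O)cc1OC` differs from compound 2 as follows: 2-(trifluoromethyl)phenyl in place of 4-fluorophenyl on a saturated chain carbon bound to an oxygen on an aromatic ring. The same difference reads 4-fluorobenzyl to 2-(trifluoromethyl)benzyl.

Among the measured compounds shown here, the only measured step is a step that the two limits leave unreadable from compound 1 to compound 2. It has no size to carry over, and it concerns a different change on the same oxygen. No measured step sizes the new change, so no step beyond the scatter is expected in this assay, and no direction can be assigned. The starting point remains compound 2, with its limit of > 10000 nM.

The estimated step is a step that the limit leaves unreadable from compound 2 to compound 3. A further limit is the most likely report, but if a number is obtained, the expected value for compound 3 is 12000 nM, with an estimated range of 4000 nM to 30000 nM.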

Compound 3, half-maximal inhibitory concentration: > 10000 nM
Compound 3 ended at the assay's limit; the forecaster's own chance of this, stated with the estimate: 80%; the middle value lies beyond the limit too.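

Compound 3 joins compound 1 and compound 2 at a limit of this assay, so no step among these three compounds can be read: the limit of > 10000 nM in this assay, at which 3 of the 3 values shown sit.

The compounds shown leave open whether any group on the oxygen on an aromatic ring gives a measurable value in this assay, and how 2-(trifluoromethyl)phenyl compares with 4-fluorophenyl there.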